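The source may hold more compounds than are shown below. What is called first, only, known or untested is meant among the compounds shown, and "the series" means these compounds.

Values in an ADME assay on HeLa cells (Homo sapiens) for cytotoxicity, read by MTT assay; on this read-out higher numbers stand for weaker inhibition and lower numbers for stronger inhibition:
- compound 1 `COc1ccc(C[C@H]2COC(=O)[C@@H]2Cc2ccc(OCc3cn(-c4ccc(F)cc4)nn3)c(OC)c2)cc1OC`: >= 600000 nM (a limit)
- compound 2 `COC(=O)CNC(=O)CCC(=O)Oc1ccc(C[C@H]2C(=O)OC[C@@H]2Cc2ccc(OC)c(OC)c2)cc1OC`: 179000 nM

Going by the values given here, compound 2, at 179000 nM, holds the only actual number so far. The entry for compound 1, >= 600000 nM, is a limit of the assay and not a number.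

Compound 3 `COc1ccc(C[C@H]2COC(=O)[C@@H]2Cc2ccc(OCC(=O)Nc3ccc(C)cc3)c(OC)c2)cc1OC` is still unmeasured. It carries ((4-methylphenyl)carbamoyl)methyl on an oxygen on an aromatic ring, in place of the group without a ring in compound 2: a group of 11 heavy atoms (9 carbon, 1 nitrogen, 1 oxygen; one six-membered aromatic ring of carbon only) in place of a group of 12 heavy atoms (7 carbon, 1 nitrogen, 4 oxygen; no ring), on an oxygen on an aromatic ring. Compound 1 also has a six-membered aromatic ring of carbon only in its side chain, so a modest shift towards weaker inhibition in this assay is expected, with a 1.7-fold higher number from compound 2 to compound 3 (0.22 log units; within the scatter) as the estimated step. Compound 3 is estimated at 300000 nM, with an expected range of 100000 nM to 600000 nM.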

Compound 3, half-maximal inhibitory concentration: 228000 nM
For compound 3 the middle estimate is 1.3-fold (0.12 log units) above the measured one; low and high end bracket the measured number.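

In this assay, ((4-methylphenyl)carbamoyl)methyl in place of the group without a ring, on an oxygen on an aromatic ring, gives a 1.3-fold higher number from compound 2 to compound 3 (0.11 log units; within the scatter), so these two side chains cannot be told apart at this position. (4-Methylphenyl)carbamoyl in place of 1-(4-fluorophenyl)-1H-1,2,3-triazol-4-yl gives an at least 2.6-fold lower number from compound 1 to compound 3 (0.42 log units; beyond the scatter). That step is only a minimum, since the entry for compound 1 is a limit and not a number: the limit of >= 600000 nM in this assay, at which 1 of the 3 values shown sits.

On these data alone, whether an amine or a carboxylic acid on this oxygen would move the number beyond the scatter remains open. Also open, as far as these compounds go, is what the methyl on the phenyl ring contributes.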